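A few compounds are considered here, and "the series" means these few. Any claim that something is new, unique, unknown or untested is made for them only; others in the source may bear on it.

In a functional assay on HCT-116 cells (Homo sapiens) for cytotoxicity, read by MTT assay, with a stated time of 48 h, in the presence of a further agent that is not named here (on this read-out lower numbers stand for an effect already at smaller amounts and higher numbers for an effect only at larger amounts of compound), three compounds have been measured so far. Compound 1 `COc1cc(NC(=O)NNc2cc(-c3ccccc3)c3cnn(C)c3n2)cc(Cl)n1` gives 31300 nM and compound 3 `Cc1ccc(NC(=O)NNc2cc(-c3ccc(F)cc3)c3cnn(C)c3n2)cc1Nc1nccc(-c2cccnc2)n1` gives 39200 nM, and these two values lie within the scatter of each other. Compound 2 `Cn1ncc2c(-c3ccccc3)cc(NNC(=O)Nc3cc(Cl)nc(Cl)c3)nc21` gives 6240 nM, a lower number than either, so compound 1 stands with compound 3 at the upper end of the numbers seen so far.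

Compound 4 `COc1ccc(-c2cc(NNC(=O)Nc3cc(Cl)nc(OC)c3)nc3c2cnn3C)cc1` has not yet been measured. It differs from compound 1 in one place: methoxy in place of hydrogen on an aromatic carbon. In words, this is methoxy in place of hydrogen on an aromatic carbon, para to a large group, which turns phenyl into 4-methoxyphenyl.

For the measured compounds named here, only one measured step changes a single place: a 5.0-fold lower number from compound 1 to compound 2 (0.70 log units; beyond the scatter), with chloro in place of methoxy on an aromatic carbon. That modest step lies beyond the scatter, but it sits in a different part of the molecule, so it does not test the phenyl. Compound 3 differs from compound 1 in more than one place and offers no clean comparison. Going by the values given here, with no measured step at this position, no step beyond the scatter is expected in either direction. The expected step is a 1.0-fold lower number from compound 1 to compound 4 (0.02 log units; within the scatter). For compound 4 the estimated value is 30000 nM, with an expected range from 12000 nM to 70000 nM.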

Compound 4, half-maximal effective concentration: 54200 nM
Estimate against measurement, compound 4: 1.8-fold (0.26 log units) below, within the range that was stated.
By their numbers in this assay, from the lowest: compound 2; then compounds 1, 3 and 4 (each within the scatter of the next).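

In this assay, the phenyl of the shared core now has its first measured change: methoxy in place of hydrogen on an aromatic carbon, para to a large group, gives a 1.7-fold higher number from compound 1 to compound 4 (0.24 log units; within the scatter) in this comparison. Turning phenyl into 4-methoxyphenyl therefore leaves compound 4 and compound 1 indistinguishable in this assay, whereas the only earlier single-place step, a 5.0-fold lower number from compound 1 to compound 2 (0.70 log units; beyond the scatter) at another part of the molecule, lay beyond the scatter. Nothing measured here accounts for this result.

From the compounds shown here alone, this single group at a single place says little about other replacements, so it remains open whether an amine or a carboxylic acid on the same aromatic carbon would also stay within the scatter of compound 1. It is also open whether 4-methoxyphenyl would leave the number just as unchanged on the background of compound 2, which carries chloro where compound 1 carries methoxy and is the only compound shown with a number clearly apart from the others.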